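The source may report more compounds than this note shows. Statements on the series, on what has been measured and on what is new or still open speak of the compounds shown alone.

Measured in a functional assay on MCF7 cells (Homo sapiens) for cytotoxicity, read by MTT assay, with a stated time of 96 h; on this read-out lower numbers stand for stronger inhibition and higher numbers for weaker inhibition:
- compound 1 `COc1cc(C(=O)c2cn(-c3ccccc3C)cc2-c2ccccc2)cc(OC)c1OC`: 2200 nM
- compound 2 `COc1cc(C(=O)c2cn(-c3ccc([N+](=O)[O-])cc3)cc2-c2ccccc2)cc(OC)c1OC`: 4000 nM

Among the compounds with values here, compound 2, at 4000 nM, lies within the scatter of compound 1, the only other measured compound. Compound 3 `COc1ccc(-n2cc(C(=O)c3cc(OC)c(OC)c(OC)c3)c(-c3ccccc3)c2)cc1` has methoxy in place of nitro on an aromatic carbon, turning 4-nitrophenyl into 4-methoxyphenyl. Within the data shown here, only one measured step bears on this: a 1.8-fold higher number from compound 1 to compound 2 (0.26 log units; within the scatter), for 4-nitrophenyl in place of 2-methylphenyl. This single step gives no sign of a large effect, so no change beyond the scatter is expected in this assay. The expected step is a 1.6-fold lower number from compound 2 to compound 3 (0.20 log units; within the scatter). Compound 3 is estimated at 2500 nM, with an expected range of 600 nM to 9000 nM.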

Compound 3, half-maximal inhibitory concentration: 120 nM
The estimate for compound 3 lay 21-fold (1.32 log units) above the measured number; measured number below the stated range.
By their numbers in this assay, from the lowest: compound 3; then compounds 1 and 2 (each within the scatter of the next).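

In this assay the earlier step stayed within the scatter, but methoxy in place of nitro brings a 33-fold lower number from compound 2 to compound 3 (1.52 log units; beyond the scatter) and so shows that this position, para to a large group, can move the number strongly. 4-Methoxyphenyl in place of 2-methylphenyl on the aromatic nitrogen also matters, with an 18-fold lower number from compound 1 to compound 3 (1.26 log units; beyond the scatter) as the step. Nothing shown here explains the size of these changes.

On these data alone, whether the gain belongs to methoxy itself or to the loss of nitro stays open. So does whether a hydroxyl, an amine or a longer chain such as ethoxy at this position would keep the number low.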